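The source may report more compounds than this note shows. Statements on the series, on what has been measured and on what is new or still open speak of the compounds shown alone.

In a functional assay on PANC-1 cells (Homo sapiens) for inhibition, read by MTT assay, with a stated time of 24 h (on this read-out higher numbers stand for weaker inhibition and lower numbers for stronger inhibition), compound 1 (`CC1(C)[C@H]2CC[C@]1(C)N(Cc1cn(-c3ccc(C#N)cc3)nn1)C(=O)C2`) gives 250 nM while compound 2 (`CC1(C)[C@H]2CC[C@]1(C)N(Cc1cn(-c3ccccc3F)nn1)C(=O)C2`) gives 150 nM and compound 3 (`CC1(C)[C@H]2CC[C@]1(C)N(Cc1cn(-c3ccc(F)cc3)nn1)C(=O)C2`) gives 110 nM on the same shared core. On these numbers compound 3 cannot be told apart from compound 2 but stands clear of compound 1. The next compound, compound 4 (`CC1(C)[C@H]2CC[C@]1(C)N(Cc1cn(-c3ccccc3)nn1)C(=O)C2`), has hydrogen in place of fluoro on an aromatic carbon, para to a large group (hydrogen in place of fluoro on an aromatic carbon), so 4-fluorophenyl becomes phenyl.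

Among the measured compounds shown here, no measured step makes exactly this change. The nearest is fluoro in place of cyano on an aromatic carbon, a 2.3-fold lower number from compound 1 to compound 3 (0.36 log units; beyond the scatter) and thus a modest step. Exchanging 2-fluorophenyl for 4-fluorophenyl moved the number less, a 1.4-fold lower number from compound 2 to compound 3 (0.13 log units; within the scatter) and so stayed within the scatter, as did a 1.7-fold lower number from compound 1 to compound 2 (0.22 log units; within the scatter) for the remaining pair. With steps this small across the aryl group, this assay is expected to show little change, and the data fix no firm direction. The expected step is a 1.3-fold higher number from compound 3 to compound 4 (0.10 log units; within the scatter) and so no step beyond the scatter is anticipated. For compound 4 the estimate is 140 nM with an expected range of 65 nM to 300 nM on this read-out.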

Compound 4, half-maximal inhibitory concentration: 160 nM
Compound 4: middle estimate off by 1.1-fold (0.06 log units), on the low side; the measured number falls inside the stated range.
By their numbers in this assay, from the lowest: compounds 3, 2, 4 and 1 (each within the scatter of the next, the first and the last beyond it).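

Among the compounds shown here, with hydrogen in place of fluoro, compound 4 supplies the first unsubstituted aryl group in this short series, giving the substituted compounds a phenyl reference in this assay. The change from 4-fluorophenyl to phenyl is a 1.5-fold higher number from compound 3 to compound 4 (0.16 log units; within the scatter), and the comparison with the fluoro of compound 2 is a 1.1-fold higher number from compound 2 to compound 4 (0.03 log units; within the scatter), while that with the cyano of compound 1 is a 1.6-fold lower number from compound 1 to compound 4 (0.19 log units; within the scatter), so neither fluoro nor cyano can be told apart from hydrogen on these numbers, and the only separation beyond the scatter remains that between compound 1 and compound 3, two substituted compounds that each lie within the scatter of compound 4. No supporting measurement is available to explain these small differences.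

The compounds shown leave open whether an amine, a carboxylic acid or a methoxy group at this place on the ring would give a step beyond the scatter from phenyl. They also leave open whether replacing the whole aryl group with a longer alkyl chain would change the number in this assay by more than the substituents on the ring have done here.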